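The source may report more compounds than this note shows. Statements on the series, on what has been measured and on what is new or still open speak of the compounds shown alone.

Working notes on the series.

Compound 1 `CCn1c(N[C@@H]2C[C@H](c3ccccc3)CN(C)C2)nc2cc[nH]c2c1=O` is the reference. In an assay on isolated protein for binding affinity to histone acetyltransferase KAT2B (Homo sapiens), read by isothermal titration calorimetry (a higher number here means weaker binding, a lower number tighter binding), compound 1 gives 621 nM, the highest of the three numbers in hand. Compound 2 `CN1C[C@H](Nc2nc3cc[nH]c3c(=O)n2C)C[C@H](c2ccc(O)cc2)C1` gives 120 nM and compound 3 `CN1C[C@H](Nc2nc3cc[nH]c3c(=O)n2C)C[C@H](c2ccc(OC(F)(F)F)cc2)C1` gives 140 nM; both differ from compound 1 in more than one place at once, so their gap to compound 1 cannot be assigned to any single change. For the measured compounds named here, the one clean step, a 1.2-fold higher number from compound 2 to compound 3 (0.07 log units; within the scatter), concerns a substituent on the aromatic ring and is unrelated to the change considered here.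

Compound 4 `C=CCn1c(N[C@@H]2C[C@H](c3ccccc3)CN(C)C2)nc2cc[nH]c2c1=O` differs from compound 1 as follows: vinyl in place of methyl on a saturated chain carbon bound to an aromatic nitrogen. Going by the values given here, no measured pair addresses this change, so the expectation rests on its small size alone: a vinyl for a methyl on the chain at the aromatic nitrogen, read further out as ethyl to allyl. The step in this assay is expected to be a 1.0-fold lower number from compound 1 to compound 4 (0.01 log units; within the scatter), that is, nothing beyond the scatter. Compound 4 is therefore estimated at 600 nM, with a range from 250 nM to 1500 nM.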

Compound 4, dissociation constant: 676 nM
Compound 4: the middle estimate sits 1.1-fold (0.05 log units) below what was measured; low and high end bracket the measured number.
By their numbers in this assay, from the lowest: compounds 2 and 3 (each within the scatter of the next); then compounds 1 and 4 (each within the scatter of the next).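

In this assay, for the compounds shown here, the first step at this position is a 1.1-fold higher number from compound 1 to compound 4 (0.04 log units; within the scatter): with vinyl in place of methyl on a saturated chain carbon bound to an aromatic nitrogen, the number stays within the scatter. Read one bond further out, ethyl and allyl are therefore not distinguished here, and the extra carbon and the double bond outside aromatic rings leave no readable mark on binding in this one pair. No supporting information on this result is available.

From the compounds shown here alone, whether a longer chain, or a chain ending in an amine or a carboxylic acid, would also stay within the scatter at this place remains open. Also open, going by these compounds, is whether the same change would read alike on the substituted aromatic rings of compound 2 and compound 3.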